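Azetidin-1-yl for dimethylamino: outlook for compound 4

The source may hold more compounds than are shown below. What is called first, only, known or untested is meant among the compounds shown, and "the series" means these compounds.

Measured compounds:
compound 1 `CCCCCCCCCCCCCCCCc1c(C)c(N(C)C)nc(C)c1O` 62%
compound 2 `CCCCCCCCCCc1c(C)c(N(C)C)nc(C)c1O` 60%
compound 3 `Cc1c(N(C)C)nc(CCCCCCCCCCO)c(O)c1C` 24%

In a functional assay on cells (Lymphocyte, Homo sapiens) for inhibition, read by flow cytometry, using a membrane potential dye, with a stated time of 16 h, tested at 100 nM (a higher number here means a stronger effect of the compound at the concentration tested, a lower number a weaker effect), compound 1 stands highest of the three numbers. Compound 2 sits closest, the step of a number 2 percentage points lower from compound 1 to compound 2 (within the scatter); compound 3 sits furthest, and its value lies beyond the scatter from that of compound 1, though the two differ in more than one place.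

Compound 4 `CCCCCCCCCCCCCCCCc1c(C)c(N2CCC2)nc(C)c1O` is not yet measured. Its change from compound 1 is azetidin-1-yl in place of dimethylamino on an aromatic carbon. Among the measured compounds shown here, no measured step touches the dimethylamino group; the only one-place step known concerns the far end of the chain and stays within the scatter. There is thus no basis for expecting a shift in either direction, so the step of a number 4 percentage points lower from compound 1 to compound 4 (within the scatter) is estimated as none beyond the scatter, with a wide range. Compound 4 is expected to give 58%, between 38% and 76%.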

Compound 4, a percentage reported as activity, at one concentration (the size of the read-out at that concentration, not a potency): 55%
For compound 4 the middle estimate is 3 percentage points above the measured one, within the range that was stated.
By their numbers in this assay, from the lowest: compound 3; then compounds 4, 2 and 1 (each within the scatter of the next).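

In this assay, azetidin-1-yl in place of dimethylamino gives a number 7 percentage points lower from compound 1 to compound 4 (within the scatter), the first step read at this aromatic carbon next to the ring nitrogen. With the hexadecyl chain in place, a four-membered non-aromatic ring at this position therefore leaves the read-out within the scatter. No available evidence gives a cause for this result. On these data alone, whether a larger ring such as pyrrolidin-1-yl or morpholin-4-yl, or a primary amino group, would keep the read-out at this position stays open. So does the effect of azetidin-1-yl on the shorter chain of compound 2.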